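Replacing butyl with isopropoxy on a shared core

The source may report more compounds than this note shows. Statements on the series, on what has been measured and on what is new or still open speak of the compounds shown alone.

- Compound 1 `CCCCc1ccc(-c2c(C)[nH]c(=O)n2C)cc1`: 10700 nM
- Compound 2 `CCCCc1ccc(-c2c(CC)[nH]c(=O)n2C)cc1`: 13900 nM

Going by the values given here, these two values come from a functional assay on brain (Rattus norvegicus, strain Wistar) for inhibition (a lower number here means a stronger inhibitor, a higher number a weaker inhibitor), and they lie within the scatter of each other, so compound 1 stands level with the only other measured compound. Compound 3 `Cc1[nH]c(=O)n(C)c1-c1ccc(OC(C)C)cc1`, not yet measured, departs from compound 1 by isopropoxy in place of butyl on an aromatic carbon. Among the compounds with values here, the one measured step, a 1.3-fold higher number from compound 1 to compound 2 (0.11 log units; within the scatter), is methyl in place of hydrogen on a saturated chain carbon bound to an aromatic carbon. It leaves the butyl group untouched and bears only indirectly on this change. Within the data shown here, no measured step shows what replacing butyl does, so no shift beyond the scatter can be expected in this assay, and the uncertainty stays wide. The expected change is a 1.1-fold higher number from compound 1 to compound 3 (0.05 log units; within the scatter). Compound 3 is estimated at 12000 nM, with an expected range of 4000 nM to 36000 nM.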

Compound 3, half-maximal inhibitory concentration: 20400 nM
The estimate for compound 3 lay 1.7-fold (0.23 log units) below the measured number; the measured number falls inside the stated range.
By their numbers in this assay, from the lowest: compounds 1, 2 and 3 (each within the scatter of the next).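

In this assay, going by these compounds alone, this is the first measured change at the aromatic carbon that carries butyl, and exchanging butyl for isopropoxy gives a 1.9-fold higher number from compound 1 to compound 3 (0.28 log units; within the scatter). The two groups have the same number of heavy atoms, and isopropoxy brings oxygen and one hydrogen-bond acceptor, yet this exchange does not separate the two compounds beyond the scatter, so this position accepts an oxygen-linked group in place of the all-carbon chain without a resolved shift. No supporting measurement is available that would explain this result.

Going by these compounds, whether a different group at this place, such as an amine, a carboxylic acid or a longer chain, would move the number beyond the scatter remains open. On these data alone, it is also open whether isopropoxy would give the same result on the core of compound 2, which carries the ethyl group.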